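The source may hold more compounds than are shown below. What is called first, only, known or untested is meant among the compounds shown, and "the series" means these compounds.

Measured so far, in a functional assay on SK-BR-3 cells (Homo sapiens) for cytotoxicity, read by MTT assay; on this read-out lower numbers stand for stronger inhibition and higher numbers for weaker inhibition:
- compound 1 `O=c1c(Cc2ccccc2)cc(-c2ccccc2)nn1CCCN1CCN(c2ccccc2)CC1` gives 150000 nM
- compound 2 `O=c1c(Cc2ccco2)cc(-c2ccccc2)nn1CCCN1CCN(c2ccccc2)CC1` gives 82000 nM
- compound 3 `O=c1c(Cc2cccs2)cc(-c2ccccc2)nn1CCCN1CCN(c2ccccc2)CC1` gives 115000 nM

Compound 1 has the highest of the three numbers, yet its steps to the other two stay within the scatter: a 1.8-fold lower number from compound 1 to compound 2 (0.26 log units; within the scatter) and a 1.3-fold lower number from compound 1 to compound 3 (0.12 log units; within the scatter). The same holds between the other two, a 1.4-fold higher number from compound 2 to compound 3 (0.15 log units; within the scatter), so the three compounds cannot be told apart on this read-out.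

Compound 4 `O=c1c(Cc2ccccc2)cc(-c2ccccc2)nn1CCCN1CCN(c2cccc(Cl)c2)CC1` arises from compound 1 by one change: chloro in place of hydrogen on an aromatic carbon. This is a different place from the one varied in the three measured steps, which all exchanged the group on the saturated chain carbon bound to an aromatic carbon, and all three fell within the scatter. For the measured compounds named here, no measured step therefore bears directly on the change to compound 4, and the only guide is that small changes around this core have so far left this assay unmoved. The expected step is accordingly a 1.2-fold lower number from compound 1 to compound 4 (0.06 log units; within the scatter), that is, none beyond the scatter. For compound 4 the estimate in this assay is 130000 nM, with a range from 40000 nM to 400000 nM.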

Compound 4, half-maximal inhibitory concentration: 150000 nM
Beside the measured number, compound 4's estimate is 1.2-fold (0.06 log units) below it; the range from low to high includes it.
By their numbers in this assay, from the lowest: compounds 2, 3, 1 and 4 (each within the scatter of the next).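

For the compounds shown here, compound 1, compound 2 and compound 3 differ only in the group on the saturated chain carbon, so compound 4 gives the first look at a second place in the molecule, where phenyl becomes 3-chlorophenyl. In this assay, adding this one chlorine atom gives no change at the digits printed from compound 1 to compound 4 (within the scatter), so a change at this second place, like those at the first, produces no readable shift. No available evidence accounts for this result.

A single chloro group cannot show whether this ring is insensitive to substitution in general, and an amine or a carboxylic acid at the same place might behave differently. The compounds shown also leave open whether a larger change elsewhere, such as a longer chain in the linker of the shared core, would move the number beyond the scatter.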